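This account rests on a few compounds, and the source may have more. Where it says the series, first, only, none or still open, it means among the compounds named here.

Measured so far in a functional assay on PC-3 cells (Homo sapiens) for cytotoxicity, read by WST assay, with a stated time of 72 h; on this read-out higher numbers stand for weaker inhibition and lower numbers for stronger inhibition:
- Compound 1 `CCCC1(c2ccc(O)cc2)C(=O)Nc2c1ccc(F)c2F`: > 1000 nM (a limit, not a number)
- Compound 2 `O=C1Nc2ccccc2C1(c1ccc(O)cc1)c1ccc(F)cc1`: > 1000 nM (a limit, not a number)
- Compound 3 `COc1ccc2c(c1C)NC(=O)C2(c1ccc(O)cc1)c1ccc(F)cc1`: 9 nM

Within the data shown here, compound 3 gives 9 nM, the only true number. The rest of the series is described by the limit of > 1000 nM in this assay, at which 2 of the 3 values shown sit, and those two values, from compound 1 and compound 2, are limits only.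

The next compound is compound 4 `COc1ccc2c(c1C)NC(=O)C2(c1ccc(O)cc1)C1CCCC1`, which carries cyclopentyl in place of 4-fluorophenyl on a saturated ring carbon.

Among the measured compounds shown here, no measured pair tests this change, so compound 3 at 9 nM is the only numerical anchor. Some weakening in this assay beyond the usual scatter is expected, though the size is uncertain. The step expected is a 3.9-fold higher number from compound 3 to compound 4 (0.59 log units; beyond the scatter), toward weaker inhibition. The estimated value for compound 4 is 35 nM, with an expected range from 6 nM to 300 nM.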

Compound 4, half-maximal inhibitory concentration: 111 nM
Compound 4: the middle estimate sits 3.2-fold (0.50 log units) below what was measured; the range from low to high includes it.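

Replacing 4-fluorophenyl with cyclopentyl on this saturated ring carbon gives a 12-fold higher number from compound 3 to compound 4 (1.09 log units; beyond the scatter), toward weaker inhibition in this assay. Among these compounds, this is the first direct reading at this position, and it shows that the group here strongly affects the result, although compound 4 keeps measurable activity at 111 nM. Compound 4 also stays clear of the ceiling that bounds the rest of the series: the limit of > 1000 nM in this assay, at which 2 of the 4 values shown sit.

Among the compounds shown here, the single step does not separate ring size from the change from an aromatic to a saturated ring, a question that phenyl without fluorine, cyclohexyl or a longer chain such as n-butyl at this carbon would address. The separate contributions of the methoxy and methyl groups on the core also remain open, since the compounds shown isolate neither.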